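Compound 2 to compound 4: changing the ring amine substituent

This account rests on a few compounds, and the source may have more. Where it says the series, first, only, none or still open, it means among the compounds named here.

In a functional assay on Daudi cells (Homo sapiens) for antiproliferative activity (a higher number here means a weaker inhibitor, a lower number a stronger inhibitor), compound 2 (`Nc1ncnc2c1c(-c1ccc(Oc3ccccc3)cc1)cn2C[C@H]1CCCN1C(CO)CO`) gives 28200 nM as its half-maximal inhibitory concentration. Compound 3 (`Nc1ncnc2c1c(-c1cccc(-n3ncc4ccccc4c3=O)c1)cn2[C@H]1CCN(C[C@@H]2CO2)C1`) gives 14600 nM in the same read-out, within the scatter of compound 2. Compound 1 (`CC(C)(C)c1ccc(COc2ccc(-c3cn([C@H]4CCN(C[C@@H]5CO5)C4)c4ncnc(N)c34)cc2)cc1`) gives 6970 nM and so lies beyond the scatter on the stronger side of compound 2.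

Compound 4 (`Nc1ncnc2c1c(-c1ccc(Oc3ccccc3)cc1)cn2C[C@H]1CCCN1C[C@@H]1CO1`) is not yet measured. It carries (oxiran-2-yl)methyl in place of 2-hydroxy-1-(hydroxymethyl)ethyl on an amine nitrogen in a ring. Going by the values given here, no step between measured compounds isolates this change, so the evidence is indirect. Compound 1 and compound 3 also carry (oxiran-2-yl)methyl on such a nitrogen, but both differ from compound 2 elsewhere too. Their values point to a moderate shift towards a stronger inhibitor, with compound 1 at 6970 nM as the lower reference. The expected step is a 3.1-fold lower number from compound 2 to compound 4 (0.50 log units; beyond the scatter) and its size is uncertain. In this assay the estimated value for compound 4 is 9000 nM with an expected range (3000 nM to 25000 nM).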

Compound 4, half-maximal inhibitory concentration: 7040 nM
Compound 4: the middle estimate sits 1.3-fold (0.11 log units) above what was measured; the range from low to high includes it.
By their numbers in this assay, from the lowest: compounds 1 and 4 (each within the scatter of the next); then compounds 3 and 2 (each within the scatter of the next).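

In this assay, going by these compounds alone, this is the first step that isolates the change on the amine nitrogen of the five-membered non-aromatic ring: (oxiran-2-yl)methyl in place of 2-hydroxy-1-(hydroxymethyl)ethyl gives a 4.0-fold lower number from compound 2 to compound 4 (0.60 log units; beyond the scatter), with the rest of the molecule held constant. Within the data shown here, compound 1 and compound 3 carry the same group but differ elsewhere too, so only this pair shows that the nitrogen substituent alone moves the number beyond the scatter. Nothing measured here bears on why the step occurs.

On these data alone, it remains open whether the three-membered ring is needed for the step, or whether a plain propyl chain or a cyclopropylmethyl group on this nitrogen would give a similar number. As far as these compounds go, the opposite configuration at the oxirane stereocentre also remains open.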